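Swapping Cyclohexyl for a Fluorinated Phenyl Amide

The source may hold more compounds than are shown below. What is called first, only, known or untested is meant among the compounds shown, and "the series" means these compounds.

Compound 3 `O=C(CN1CCC(c2cccc[n+]2[O-])CC1)NC1CCCCC1` gives 58% in a functional assay on HEK293 cells for agonist activity at D(4) dopamine receptor (Homo sapiens), read by FLIPR; a higher number here means a larger maximal response, a lower number a smaller maximal response. Among the three measured amides it holds the second highest number: compound 2 `CSc1cccc(NC(=O)CN2CCC(c3cccc[n+]3[O-])CC2)c1` gives 56%, within the scatter of it, while compound 1 `O=C(CN1CCC(c2cccc[n+]2[O-])CC1)Nc1cccc(Cl)c1` gives 76%, with the step of a number 18 percentage points lower from compound 1 to compound 3 (beyond the scatter) lying beyond the scatter. Compound 4 `Cc1cc(F)ccc1NC(=O)CN1CCC(c2cccc[n+]2[O-])CC1` differs from compound 3 by 4-fluoro-2-methylphenyl in place of cyclohexyl on an amide-type nitrogen. The measured steps that bear on an aryl group replacing cyclohexyl point two ways: a number 18 percentage points lower from compound 1 to compound 3 (beyond the scatter) was modest and downward, so its reverse would be upward, whereas a number 2 percentage points higher from compound 2 to compound 3 (within the scatter) stayed within the scatter. For compound 4 a small to modest rise is therefore expected, a number 10 percentage points higher from compound 3 to compound 4 (within the scatter). Compound 4 is estimated to reach 68%, with a range from 52% to 84%.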

Compound 4, largest response reached (reported as efficacy), in percent of the reference or control that the assay uses: 84%
Compound 4: middle estimate off by 16 percentage points, on the low side; the measured number falls inside the stated range.
By their numbers in this assay, from the lowest: compounds 2 and 3 (each within the scatter of the next); then compounds 1 and 4 (each within the scatter of the next).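

On the amide-type nitrogen, an aromatic ring can clearly outdo cyclohexyl in this assay: 4-fluoro-2-methylphenyl gives a number 26 percentage points higher from compound 3 to compound 4 (beyond the scatter). Having a phenyl group is not enough on its own, since this group also gives a number 28 percentage points higher from compound 2 to compound 4 (beyond the scatter), although compound 2 carries a phenyl ring too. Two differently substituted phenyl groups can also sit together, with a number 8 percentage points higher from compound 1 to compound 4 (within the scatter).

No measurement here explains these differences. Going by these compounds, it remains open whether the fluoro or the methyl group matters more, and how an amine or a carboxylic acid on that phenyl ring would read.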